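Replacing trifluoromethylphenyl with methylphenyl on the cyclopropane diamide

The compounds below may be only part of what the source reports. "The series", "measured", "known", "first", "only" and "open" are said of these compounds alone.

Measured so far:
compound 1, `CN(C)C(=O)c1cc2cnc(Nc3ccc(NC(=O)C4(C(=O)Nc5ccccc5F)CC4)cc3)nc2n1C1CCCC1`, 85.2%
compound 2, `CN(C)C(=O)c1cc2cnc(Nc3ccc(NC(=O)C4(C(=O)Nc5cccc(O)c5)CC4)cc3)nc2n1C1CCCC1`, 80.7%
compound 3, `CN(C)C(=O)c1cc2cnc(Nc3ccc(NC(=O)C4(C(=O)Nc5cccc(C(F)(F)F)c5)CC4)cc3)nc2n1C1CCCC1`, 9.7%

In a functional assay on T47D cells (Homo sapiens) for inhibition, read by CCK-8 assay, with a stated time of 72 h, tested at 1 uM (a lower number here means less inhibition of growth, a higher number more inhibition of growth at the concentration tested), compound 3 stands lowest of the three; its nearest neighbour is compound 2, with a number 71 percentage points lower from compound 2 to compound 3 (beyond the scatter), and the furthest is compound 1, with a number 75.5 percentage points lower from compound 1 to compound 3 (beyond the scatter). Between compounds 1 and 2 the numbers lie close, a number 4.5 percentage points lower from compound 1 to compound 2 (within the scatter).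

Compound 4, `Cc1ccc(NC(=O)C2(C(=O)Nc3ccc(Nc4ncc5cc(C(=O)N(C)C)n(C6CCCC6)c5n4)cc3)CC2)cc1`, is not yet measured. It differs from compound 3 in one place: 4-methylphenyl in place of 3-(trifluoromethyl)phenyl on an amide-type nitrogen.

Both large steps in this assay concern the aryl group on that amide-type nitrogen, and both run toward compound 3 as the low end: the 3-(trifluoromethyl)phenyl compound sits far below the 2-fluorophenyl and 3-hydroxyphenyl compounds. No step involving 4-methylphenyl has been measured, so the direction rests only on compound 3 being the outlier among these three aryl amides. On that basis compound 4 is expected to recover much of the inhibition, with an estimated step of a number 50.3 percentage points higher from compound 3 to compound 4 (beyond the scatter) in this assay. Compound 4 is therefore estimated at 60%, within a range of 20% to 90%.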

Compound 4, percent growth inhibition at one concentration: 47.9%
Compound 4: the middle estimate sits 12.1 percentage points above what was measured; the range from low to high includes it.
By their numbers in this assay, from the lowest: compound 3; then compound 4; then compounds 2 and 1 (each within the scatter of the next).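

In this assay the step from 3-(trifluoromethyl)phenyl to 4-methylphenyl on the amide-type nitrogen is a number 38.2 percentage points higher from compound 3 to compound 4 (beyond the scatter), so an aryl group with no hydrogen-bond donor or acceptor need not sit at the low end. The same compound also stays clear of the two high compounds, with a number 32.8 percentage points lower from compound 2 to compound 4 (beyond the scatter) and a number 37.3 percentage points lower from compound 1 to compound 4 (beyond the scatter), and this position now shows three separate levels instead of one low compound set against two close ones. Nothing available here accounts for these levels.

The compounds shown do not separate the exchange of trifluoromethyl for methyl from the different numbering of the two groups on the phenyl ring. Going by these compounds, a 3-methylphenyl or a 4-(trifluoromethyl)phenyl group would bear on that question, and how a 4-aminophenyl group would behave here remains open.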